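A few compounds are considered here, and "the series" means these few. Any claim that something is new, unique, unknown or untested is made for them only; others in the source may bear on it.

Of the compounds shown here, two sharing one core have been measured so far in a functional assay on T98G cells (Homo sapiens) for inhibition, read by MTT assay, with a stated time of 72 h; on this read-out higher numbers stand for weaker inhibition and lower numbers for stronger inhibition. Compound 1 (`COc1ccc(NC(=S)NC2CC(C)(C)Oc3ccc(Br)cc32)cc1`) gives 33000 nM, and compound 2 (`COc1cccc(NC(=S)NC2CC(C)(C)Oc3ccc(Br)cc32)c1`) gives 87000 nM, the higher of the two numbers and so the weaker inhibition of this pair. Compound 3 (`CC1(C)CC(NC(=S)Nc2ccccc2Cl)c2cc(Br)ccc2O1`) keeps the shared core but carries 2-chlorophenyl in place of 3-methoxyphenyl on an amide-type nitrogen. Its value in this assay is not yet known.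

Among the compounds with values here, only one measured step bears on this change: a 2.6-fold higher number from compound 1 to compound 2 (0.42 log units; beyond the scatter). That modest step swapped 4-methoxyphenyl for 3-methoxyphenyl on the same nitrogen, so it shows that this place can shift the number. Within the data shown here, it says nothing directly about 2-chlorophenyl, and no compound with a chlorine on this group has been measured. The expectation therefore rests on thin evidence: a step of similar modest size, leaning towards a lower number, with compound 1 at 33000 nM as the only lower reference. The expected change is a 2.2-fold lower number from compound 2 to compound 3 (0.34 log units; beyond the scatter). Compound 3 is estimated at 40000 nM, with an expected range of 15000 nM to 100000 nM.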

Compound 3, half-maximal inhibitory concentration: 8000 nM
For compound 3 the middle estimate is 5.0-fold (0.70 log units) above the measured one; the whole stated range lies above it.
By their numbers in this assay, from the lowest: compound 3; then compound 1; then compound 2.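

In this assay, replacing 3-methoxyphenyl with 2-chlorophenyl on the amide-type nitrogen gives an 11-fold lower number from compound 2 to compound 3 (1.04 log units; beyond the scatter), a large step that goes well beyond the modest 2.6-fold higher number from compound 1 to compound 2 (0.42 log units; beyond the scatter) seen between the two methoxyphenyl groups. Replacing 4-methoxyphenyl with the same 2-chlorophenyl group gives a 4.1-fold lower number from compound 1 to compound 3 (0.62 log units; beyond the scatter), so the gain holds against both earlier compounds, and compound 3 is the strongest inhibitor of the three on this read-out. This position can therefore change the number much more than the methoxyphenyl pair suggested, and the move towards stronger inhibition comes with a change of group rather than a shift of the methoxy group alone, though no measured evidence here explains why the number falls.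

With a single chlorine-bearing compound in view, the compounds shown leave open whether the chlorine itself matters or whether other groups at the same place on the ring, such as bromine, methyl or trifluoromethyl, would do as well. On these data alone, it also remains open how plain phenyl or a ring carrying an amine would compare on this nitrogen.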